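Replacing the benzyl amine with a piperidinylethyl amine

A few compounds are considered here, and "the series" means these few. Any claim that something is new, unique, unknown or untested is made for them only; others in the source may bear on it.

Compound 2 `CCCN(Cc1ccccc1)c1cccc(C(=O)N2CCc3ccc(OS(N)(=O)=O)cc3C2)c1` gives 23.1% in an assay on HEK293 cells for inhibition of Steryl-sulfatase (Homo sapiens), tested at 0.1 uM (a lower number here means a weaker effect, a higher number a stronger effect of the compound at the concentration tested), and compound 1 `CCN(Cc1ccccc1)c1cccc(C(=O)N2CCc3ccc(OS(N)(=O)=O)cc3C2)c1` gives 17.3% in this assay; the step of a number 5.8 percentage points higher from compound 1 to compound 2 (within the scatter) separates them, so the two numbers are not told apart. Compound 3 `CN(CCN1CCCCC1)c1cccc(C(=O)N2CCc3ccc(OS(N)(=O)=O)cc3C2)c1` differs from compound 2 by methyl(2-(piperidin-1-yl)ethyl)amino in place of benzyl(propyl)amino on an aromatic carbon. Among the measured compounds shown here, no measured step covers such an exchange of the whole amine substituent; the one step known concerns only a chain carbon and stayed within the scatter, so no direction can be argued. Compound 3 is expected to shift by a number 3.1 percentage points lower from compound 2 to compound 3 (within the scatter), with no change beyond the scatter. Compound 3 is estimated at 20%, between 3% and 42%.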

Compound 3, a percentage reported as inhibition, at one concentration (the size of the read-out at that concentration, not a potency): 24.5%
Beside the measured number, compound 3's estimate is 4.5 percentage points below it; low and high end bracket the measured number.
By their numbers in this assay, from the lowest: compounds 1, 2 and 3 (each within the scatter of the next).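

Exchanging the whole amine substituent on the aromatic carbon gives a number 1.4 percentage points higher from compound 2 to compound 3 (within the scatter) and a number 7.2 percentage points higher from compound 1 to compound 3 (within the scatter) in this assay and so leaves all three compounds not told apart. Benzyl(propyl)amino or benzyl(ethyl)amino can give way to methyl(2-(piperidin-1-yl)ethyl)amino, with its non-aromatic ring in place of the aromatic one, and this read-out registers no difference at this position. No evidence at hand accounts for this result. Still open, from the compounds shown here alone, is whether a morpholine ring in place of the piperidine, or a carboxylic acid on this chain, would move the number beyond the scatter.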